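Replacing 4-hydroxyphenyl with 2,6-dimethoxyphenyl in a growth inhibitor

The compounds below may be only part of what the source reports. "The series", "measured", "known", "first", "only" and "open" are said of these compounds alone.

In a functional assay on SK-MEL-5 cells (Homo sapiens) for inhibition, read by sulforhodamine B assay, with a stated time of 48 h (a higher number here means a weaker inhibitor of growth, a lower number a stronger inhibitor of growth), compound 1 `O=C(Cc1csc2nc(-c3ccc(Br)cc3)cn12)N/N=C/c1ccccc1` gives 26900 nM, and compound 2 `O=C(Cc1csc2nc(-c3ccc(Br)cc3)cn12)N/N=C/c1ccc(O)cc1` gives 22400 nM. Going by the values given here, compound 2 therefore stands level with compound 1, the only other measured compound, and neither can be separated from the other on these numbers.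

Compound 3 `COc1cccc(OC)c1/C=N/NC(=O)Cc1csc2nc(-c3ccc(Br)cc3)cn12` keeps the shared core and differs from compound 2 in one place: 2,6-dimethoxyphenyl in place of 4-hydroxyphenyl on a carbon with a double bond to nitrogen. In words, 2,6-dimethoxyphenyl stands in place of 4-hydroxyphenyl on a carbon with a double bond to nitrogen.

Among the compounds with values here, only one measured step bears on this change, and it concerns the same aromatic ring. That step, a 1.2-fold lower number from compound 1 to compound 2 (0.08 log units; within the scatter), came with hydroxy in place of hydrogen on an aromatic carbon and stayed within the scatter. Within the data shown here, no measured compound carries a methoxy group, so the data give only weak guidance and no direction. In this assay no shift beyond the scatter is expected, and the estimated change is a 1.1-fold higher number from compound 2 to compound 3 (0.03 log units; within the scatter). For compound 3 the estimate is 24000 nM, with an expected range of 11000 nM to 50000 nM.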

Compound 3, concentration for total growth inhibition: 42700 nM
Beside the measured number, compound 3's estimate is 1.8-fold (0.25 log units) below it, and the stated range covers the measured number.
By their numbers in this assay, from the lowest: compounds 2, 1 and 3 (each within the scatter of the next).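

In this assay, the step from a hydroxylated ring to one carrying two methoxy groups on the carbon with a double bond to nitrogen is a 1.9-fold higher number from compound 2 to compound 3 (0.28 log units; within the scatter), and the comparison with the unsubstituted ring is a 1.6-fold higher number from compound 1 to compound 3 (0.20 log units; within the scatter). The position therefore accepts 2,6-dimethoxyphenyl, which has more heavy atoms than 4-hydroxyphenyl and has hydrogen-bond acceptors but no donor, without any shift that can be told from the scatter, so phenyl, 4-hydroxyphenyl and 2,6-dimethoxyphenyl remain inseparable here. Nothing available bears on why the numbers fall as they do.

The compounds shown leave open whether any group on this aromatic ring, such as an amine or a carboxylic acid, can move the number beyond the scatter, since the three rings give no direction. They also leave open what each part of the change contributes, since compound 3 loses the hydroxy and gains both methoxy groups in one step, and a ring with a single methoxy group would be needed to separate these contributions.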